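A few compounds are considered here, and "the series" means these few. Any claim that something is new, unique, unknown or untested is made for them only; others in the source may bear on it.

Measured in an in vivo functional assay on the whole organism (MDA-MB-435 cells, Homo sapiens) for antiproliferative activity; a lower number here means a stronger inhibitor, a higher number a weaker inhibitor:
- compound 1 `CO[C@@H](C(=O)NC1CC[C@@H](OC(=O)c2ccccc2)CNC1=O)[C@H](O)[C@@H](O)[C@H](O)/C=C/C(C)(C)C`: 370 nM
- compound 2 `CO[C@@H](C(=O)NC1CC[C@@H](OC(=O)CC2CCCCC2)CNC1=O)[C@H](O)[C@@H](O)[C@H](O)/C=C/C(C)(C)C`: 60 nM
- compound 3 `CCCCCCCCCCCCCC(=O)O[C@@H]1CCC(NC(=O)[C@H](OC)[C@H](O)[C@@H](O)[C@H](O)/C=C/C(C)(C)C)C(=O)NC1`: < 10 nM (a limit, not a number)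

Compound 3 gives only a limit, < 10 nM. Compound 4 `CO[C@@H](C(=O)NC1CC[C@@H](OC(=O)CCc2cccnc2)CNC1=O)[C@H](O)[C@@H](O)[C@H](O)/C=C/C(C)(C)C` has pyridin-3-yl in place of undecyl on a saturated chain carbon, two bonds along the chain from a carbonyl carbon.

Among the compounds with values here, two measured steps bear on this change. The first is a 6.2-fold lower number from compound 1 to compound 2 (0.79 log units; beyond the scatter), and the second, closer one is an at least 6.0-fold lower number from compound 2 to compound 3 (0.77 log units; beyond the scatter), which introduced the long chain that compound 4 gives up. Compound 4 carries a ring, as do compound 1 and compound 2, so the gain from the second step is expected to be lost. A rise of modest size or more is therefore expected in this assay, towards a weaker inhibitor, with compound 4 expected to fall in the region of compound 2 (60 nM) and compound 1 (370 nM).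

The expected step is an at least 15-fold higher number from compound 3 to compound 4 (1.17 log units; beyond the scatter). For compound 4 the estimated value is 150 nM, with an expected range of 40 nM to 600 nM.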

Compound 4, half-maximal inhibitory concentration: 460 nM
Compound 4: middle estimate off by 3.1-fold (0.49 log units), on the low side; low and high end bracket the measured number.
By their numbers in this assay, from the lowest: compound 2; then compounds 1 and 4 (each within the scatter of the next). At a limit, below all of these: compound 3.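

In this assay, the exchange of undecyl for pyridin-3-yl gives an at least 46-fold higher number from compound 3 to compound 4 (1.66 log units; beyond the scatter), which shows that the level reached with the long chain does not survive this change at this position. A ring at the end of the ester does not by itself set the level, since the shift to (pyridin-3-yl)methyl from cyclohexyl gives a 7.7-fold higher number from compound 2 to compound 4 (0.88 log units; beyond the scatter). The exchange of phenyl for 2-(pyridin-3-yl)ethyl on the carbonyl carbon gives a 1.2-fold higher number from compound 1 to compound 4 (0.09 log units; within the scatter), so these two esters cannot be told apart here.

The value of compound 3 is a limit, so the first step has no measured upper end: the limit of < 10 nM in this assay, at which 1 of the 4 values shown sits. Open too, going by these compounds, is where a phenyl ring at this same place, or a shorter alkyl chain such as hexyl, would stand, and so whether the ring nitrogen of compound 4 matters at all.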